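Methoxy added to the distal aromatic ring of compound 2

The compounds below may be only part of what the source reports. "The series", "measured", "known", "first", "only" and "open" are said of these compounds alone.

Compound 1, `CCCCN1CCC(CCC(=O)c2cc(Cl)c(N)c3c2OCCO3)CC1`: 9.9
Compound 2, `Nc1c(Cl)cc(C(=O)CCC2CCN(CCCc3ccccc3)CC2)c2c1OCCO2`: 9.6

Of the compounds shown here, two have been measured. In an assay for antagonist activity at 5-hydroxytryptamine receptor 4 (Rattus norvegicus) (on this read-out lower numbers stand for lower potency and higher numbers for higher potency (the scale is a negative logarithm)), compound 1 gives 9.9, and in this assay compound 2 gives 9.6. Going by the values given here, compound 2 stands alongside compound 1, since the single known step, a number 0.30 log units lower from compound 1 to compound 2 (within the scatter), is within the scatter, so the two numbers cannot be told apart.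

Compound 3, `COc1ccc(CCCN2CCC(CCC(=O)c3cc(Cl)c(N)c4c3OCCO4)CC2)cc1`, carries the same core and the same chain as compound 2 and differs in one place: methoxy in place of hydrogen on an aromatic carbon.

Among the compounds with values here, no measured step touches a substituent on that aromatic ring. Within the data shown here, the only step available, a number 0.30 log units lower from compound 1 to compound 2 (within the scatter), concerns the exchange of a methyl for a phenyl on the chain and was itself within the scatter; it does not bear directly on a methoxy group placed on the ring. With nothing pointing either way, the step from compound 2 to compound 3 is expected to be none beyond the scatter, a number 0.10 log units lower from compound 2 to compound 3 (within the scatter). Compound 3 is accordingly estimated at 9.5 in this assay, with a range from 9 to 10.1.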

Compound 3, negative logarithm of the antagonist equilibrium constant: 10.6
Estimate against measurement, compound 3: 1.10 log units below; measured number outside the range, above it.
By their numbers in this assay, from the lowest: compounds 2 and 1 (each within the scatter of the next); then compound 3.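

In this assay, the phenyl ring of compound 2 proves to be a place where a small addition counts: methoxy in place of hydrogen on an aromatic carbon, para to a large group, gives a number 1.00 log units higher from compound 2 to compound 3 (beyond the scatter) and so moves the number beyond the scatter. The earlier exchange at the chain end, a number 0.30 log units lower from compound 1 to compound 2 (within the scatter), could not be told from the scatter, whereas 4-methoxyphenyl in place of the same methyl gives a number 0.70 log units higher from compound 1 to compound 3 (beyond the scatter) and makes compound 3 the most potent of the three in this assay. The end of this chain can therefore separate compounds in this assay once the ring carries methoxy, although nothing available explains why the number rises.

The compounds shown leave open whether this gain is specific to methoxy, since no compound here carries a hydroxyl, a fluorine or a methyl on that same aromatic carbon. They also leave open whether methoxy on another carbon of the ring, or an ethoxy group in its place, would give a comparable step.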